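This account rests on a few compounds, and the source may have more. Where it says the series, first, only, none or still open, it means among the compounds named here.

Three compounds built on a shared core were tested in a functional assay on Ehrlich cells (Mus musculus) for cytotoxicity, tested at 100 ug/mL; a higher number here means a stronger effect of the compound at the concentration tested, a lower number a weaker effect. Compound 1 `COc1cc(N2C(N)=C(C#N)C(c3c(O)ccc4ccccc34)C3=C2CC(C)(C)CC3=O)cc(OC)c1OC` gives 90%. Compound 2 `COc1cc(N2C(N)=C(C#N)C(c3cccs3)C3=C2CC(C)(C)CC3=O)cc(OC)c1OC` gives 20%. Compound 3 `COc1cc(N2C(N)=C(C#N)C(c3ccc(O)cc3)C3=C2CC(C)(C)CC3=O)cc(OC)c1OC` gives 100%, the highest of the three numbers, though its gap to compound 1 is within the scatter, so only compound 2 stands clearly lower. The step of a number 70 percentage points lower from compound 1 to compound 2 (beyond the scatter) and the step of a number 80 percentage points higher from compound 2 to compound 3 (beyond the scatter) show that thiophen-2-yl on the saturated ring carbon goes with a far weaker effect than either of the other two groups, while the step of a number 10 percentage points higher from compound 1 to compound 3 (within the scatter) stays within the scatter.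

Compound 4 `COc1cc(N2C(N)=C(C#N)C(c3ccccc3O)C3=C2CC(C)(C)CC3=O)cc(OC)c1OC` is not yet measured. It differs from compound 3 by 2-hydroxyphenyl in place of 4-hydroxyphenyl on a saturated ring carbon. Going by the values given here, the step that bears most on this change is the one from compound 1 to compound 3, where a different aromatic group carrying a hydroxyl group made no difference beyond the scatter, as a number 10 percentage points higher from compound 1 to compound 3 (within the scatter) shows; on that basis a step of a number 10 percentage points lower from compound 3 to compound 4 (within the scatter) is expected, that is, none beyond the scatter. Compound 4 is therefore estimated at 90%, with a range from 70% to 100%.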

Compound 4, a percentage reported as activity, at one concentration (the size of the read-out at that concentration, not a potency): 10%
The estimate for compound 4 lay 80 percentage points above the measured number; the measured number lies below the stated range.
By their numbers in this assay, from the lowest: compounds 4 and 2 (each within the scatter of the next); then compounds 1 and 3 (each within the scatter of the next).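

In this assay, the two compounds have the same atoms and differ only in where the hydroxyl sits on the phenyl ring, yet the change to 2-hydroxyphenyl gives a large loss (a number 90 percentage points lower from compound 3 to compound 4 (beyond the scatter)), so at this saturated ring carbon the hydroxyl's location on the ring matters, not just its presence. The new compound lies within the scatter of the thiophen-2-yl compound (a number 10 percentage points lower from compound 2 to compound 4 (within the scatter)) and far from the 2-hydroxynaphthalen-1-yl compound (a number 80 percentage points lower from compound 1 to compound 4 (beyond the scatter)), so carrying a hydroxyl on an aromatic group does not by itself go with a strong effect. No available evidence accounts for this gap.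

Going by these compounds, whether 3-hydroxyphenyl would behave like 4-hydroxyphenyl or like 2-hydroxyphenyl remains open. So does whether 4-methoxyphenyl or 4-aminophenyl would keep the strong effect seen with 4-hydroxyphenyl.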